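The source may report more compounds than this note shows. Statements on the series, on what has been measured and on what is new or still open speak of the compounds shown alone.

Measured so far in an ADME assay on microsomes from liver (Homo sapiens) for metabolic stability, read by LC-MS, using NADPH, with a stated time of 10 min, tested at 10 uM; on this read-out higher numbers stand for a longer-lived compound and lower numbers for a shorter-lived compound 
- compound 1 `Nc1ncnc2c1c(Oc1cc(C(F)(F)F)ccn1)nn2[C@H]1CC[C@@H](CO)CC1` gives 1.6 h 
- compound 2 `CO[C@H]1CC[C@@H](n2nc(Oc3cc(C(F)(F)F)ccn3)c3c(N)ncnc32)CC1` gives 0.317 h 

Among the measured compounds shown here, compound 2 is the lower of the only two numbers in this assay so far. The next compound is compound 3 `Nc1ncnc2c1c(Oc1cc(C(F)(F)F)ccn1)nn2C1CCC1` with the change cyclobutyl in place of 4-methoxycyclohexyl on an aromatic nitrogen in which cyclobutyl takes the place of 4-methoxycyclohexyl on an aromatic nitrogen.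

For the measured compounds named here, only one measured step bears on this, and only indirectly. It is a 5.0-fold lower number from compound 1 to compound 2 (0.70 log units; beyond the scatter) and is modest. It swaps methoxy in for hydroxymethyl on a saturated ring carbon, whereas compound 3 replaces the whole ring, a kind of change not yet measured in this series. That step therefore gives a scale and no more, and a step of similar or smaller size is expected. Upward is favoured only weakly: compound 2 sits at 0.317 h at the bottom of a range of two values, and no measured step fixes the direction. The expected step is a 2.2-fold higher number from compound 2 to compound 3 (0.34 log units; beyond the scatter) by this estimate. Compound 3 is expected at 0.7 h within an estimated range of 0.25 h to 2 h as a working figure.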

Compound 3, half-life: 1.02 h
Estimate against measurement, compound 3: 1.5-fold (0.16 log units) below; low and high end bracket the measured number.
By their numbers in this assay, from the lowest: compound 2; then compounds 3 and 1 (each within the scatter of the next).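

Working notes on the substituent on the aromatic nitrogen: in this assay the whole ring at this position can be exchanged, and cyclobutyl in place of 4-methoxycyclohexyl gives a 3.2-fold higher number from compound 2 to compound 3 (0.51 log units; beyond the scatter) on the half-life. Cyclobutyl in place of 4-(hydroxymethyl)cyclohexyl gives a 1.6-fold lower number from compound 1 to compound 3 (0.20 log units; within the scatter), so these two compounds stand level, and among the three compounds the short half-life belongs to compound 2 alone, with 4-methoxycyclohexyl as its substituent. Nothing available on the compounds explains these steps.

The compounds shown leave open whether the short half-life of compound 2 goes with the methoxy group or with the methoxy group and the six-membered ring together, a question that unsubstituted cyclohexyl or cyclobutyl bearing methoxy would address directly. Also open, going by these compounds, is how the half-life responds to an amine or a carboxylic acid on the saturated ring, or to an open-chain group such as isopropyl on the aromatic nitrogen, and the three compounds say nothing about changes elsewhere on the shared core.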